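Swapping a pyridinylmethoxy ether for a cyclobutylmethoxy ether

The compounds below may be only part of what the source reports. "The series", "measured", "known", "first", "only" and "open" are said of these compounds alone.

Of the compounds shown here, two have been measured in a physicochemical assay for lipophilicity, read by HPLC, at pH 7.4; a lower number here means a more polar compound, a higher number a more lipophilic compound. Compound 1 `C[C@@H](Oc1cc2onc(CCC(=O)O)c2cc1Cl)c1ccc(F)cn1` gives 2.47 in this assay. Compound 2 `O=C(O)CCn1c(=O)oc2cc(OCc3ccccn3)c(Cl)cc21` gives 1.32 in this assay, the lower of the two numbers; compound 1 lies higher, and the gap between them is beyond the scatter. Among the compounds with values here, no step between measured compounds that differ in one place only is available, so the pair shows only what its two values show.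

Compound 3 `O=C(O)CCn1c(=O)oc2cc(OCC3CCC3)c(Cl)cc21` has not yet been measured. It differs from compound 2 in one place: cyclobutyl in place of pyridin-2-yl on a saturated chain carbon bound to an oxygen on an aromatic ring. A group with one six-membered aromatic ring holding one hetero atom and one hydrogen-bond acceptor leaves, and a group with one four-membered ring of carbon only and no hydrogen-bond acceptor enters.

The step from compound 2 to compound 3 in this assay is expected to be an increase beyond the scatter, a number 1.08 log units higher from compound 2 to compound 3 (beyond the scatter). Compound 3 is therefore estimated to give 2.4 in this assay, with a range from 1.9 to 2.9.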

Compound 3, distribution coefficient: 2.9
For compound 3 the middle estimate is 0.50 log units below the measured one; low and high end bracket the measured number.
By their numbers in this assay, from the lowest: compound 2; then compound 1; then compound 3.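

With cyclobutyl in place of pyridin-2-yl on a saturated chain carbon bound to an oxygen on an aromatic ring, this assay shows a number 1.58 log units higher from compound 2 to compound 3 (beyond the scatter). Unlike the earlier pair, which differs in more than one place, this step ties a large change in the read-out to this one position, with the rest of the structure held the same. The group that leaves brings a six-membered aromatic ring with one hetero atom and one hydrogen-bond acceptor, the group that enters a four-membered ring of carbon only with no such acceptor, and no measurement at hand says which of these differences accounts for the step.

A single step cannot separate the loss of the ring nitrogen from the loss of the aromatic ring or the change in ring size, and phenyl or cyclohexyl at this place would be needed to divide them. As far as these compounds go, whether the same exchange gives a step of similar size on the core of compound 1, where a methyl group also sits on the ether carbon, stays open as well.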